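This account rests on a few compounds, and the source may have more. Where it says the series, first, only, none or still open, it means among the compounds named here.

Among the measured compounds shown here, in a functional assay on HCT-116 cells (Homo sapiens) for cytotoxicity, read by MTT assay, with a stated time of 72 h (a lower number here means a stronger inhibitor, a higher number a weaker inhibitor), compound 1 `O=C1C=CCC/C1=C\C=C\c1ccccc1` gives 5400 nM, the only true number so far. Compound 2 `O=C1C=CCC/C1=C\C(Br)=C\c1ccccc1` reads > 10000 nM, which is a limit of the assay and not a number. Compound 3 `CC(=O)Oc1ccc(/C=C/C=C2\CCC=CC2=O)cc1` differs from compound 1 by acetoxy in place of hydrogen on an aromatic carbon, with acetoxy in place of hydrogen on an aromatic carbon. For the measured compounds named here, the only measured step, an at least 1.8-fold higher number from compound 1 to compound 2 (0.26 log units; that floor lies within the scatter), places bromo on the chain rather than on the aromatic ring, so it bears only loosely on this change. No shift beyond the scatter is therefore expected in this assay. The expected change is a 1.1-fold lower number from compound 1 to compound 3 (0.03 log units; within the scatter). For compound 3 the estimated value is 5000 nM, with an expected range of 1800 nM to 14000 nM.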

Compound 3, half-maximal inhibitory concentration: 4600 nM
For compound 3 the middle estimate is 1.1-fold (0.04 log units) above the measured one; the measured number falls inside the stated range.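

In this assay, acetoxy in place of hydrogen on an aromatic carbon, para to a large group, gives a 1.2-fold lower number from compound 1 to compound 3 (0.07 log units; within the scatter). Among the compounds shown here, this is the first measured step on the aromatic ring, and it shows that this carbon carries acetoxy, with its 4 heavy atoms, without a shift beyond the scatter. Nothing measured here gives a cause for this step. On these data alone, whether an amine or a carboxylic acid on this same carbon would read like acetoxy stays open. Other carbons of the aromatic ring also remain open, so one step sets no trend for the ring.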